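Clearance after replacing the amide substituent of compound 1

The compounds below may be only part of what the source reports. "The series", "measured", "known", "first", "only" and "open" are said of these compounds alone.

In an in vitro ADME assay on microsomes from liver (Homo sapiens) for pharmacokinetics (on this read-out higher numbers stand for fast clearance and lower numbers for slow clearance), compound 1 (`Cc1ccc(S(=O)(=O)N2C=CNC(=O)[C@H]2CC(=O)NC2CCNc3ccccc32)cc1`) gives < 50 mL.min-1.g-1 as a limit of the assay and not a number. In this assay compound 3 (`Cc1ccc(S(=O)(=O)N2C=CNC(=O)[C@H]2CC(=O)N[C@@H]2CCC(O)c3ccccc32)cc1`) gives < 50 mL.min-1.g-1 as a limit as well. Compound 1 thus stands at the limit of < 50 mL.min-1.g-1 in this assay, at which 2 of the 3 values shown sit, and has no exact number. Compound 2 (`CC(=O)N1CCC(NC(=O)C[C@@H]2C(=O)NC=CN2S(=O)(=O)c2ccc(C)cc2)c2ccccc21`) reads 450 mL.min-1.g-1 as a measured number. Its acetyl in place of hydrogen on a nitrogen on an aromatic ring in a ring gives an at least 9.0-fold higher number from compound 1 to compound 2 (0.95 log units; beyond the scatter) and this lies beyond the scatter.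

The change to compound 4 (`Cc1ccc(S(=O)(=O)N2C=CNC(=O)[C@H]2CC(=O)NC2CCOCC2(C)C)cc1`) is a group of 8 heavy atoms (7 carbon, 1 oxygen; one six-membered non-aromatic ring with 1 hetero atom) in place of a group of 10 heavy atoms (9 carbon, 1 nitrogen; one six-membered non-aromatic ring with 1 hetero atom, one six-membered aromatic ring of carbon only), on an amide-type nitrogen on an amide-type nitrogen. Among the compounds with values here, compound 4 carries no acetyl, so the only measured step, an at least 9.0-fold higher number from compound 1 to compound 2 (0.95 log units; beyond the scatter) in size, bears on this change only loosely. The expected step is a number no lower from compound 1 to compound 4 (the limit leaves the size open) and it is estimated to stay within the scatter, with no firm direction. For compound 4 the estimate is 50 mL.min-1.g-1 with an expected range from 20 mL.min-1.g-1 to 150 mL.min-1.g-1 in this read-out.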

Compound 4, intrinsic clearance in microsomes: < 100 mL.min-1.g-1
Compound 4 gave a limit, no number (the forecaster's own chance of this, stated with the estimate: 55%); the middle value does not contradict the limit.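

In this assay compound 4 gives < 100 mL.min-1.g-1, a limit of the assay and not a number. Compound 1 also stands at a limit, so the step between compound 1 and compound 4 cannot be read. The compounds shown leave open whether this change of amide substituent alters clearance at all.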